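Ethynyl in place of azido: cytotoxicity outlook for compound 3

A few compounds are considered here, and "the series" means these few. Any claim that something is new, unique, unknown or untested is made for them only; others in the source may bear on it.

Compound 1 `Cc1cn([C@H]2C[C@H](O)[C@](CO)(N=[N+]=[N-])S2)c(=O)[nH]c1=O` is known in an ADME assay on M8166 cells (Homo sapiens) for cytotoxicity, read by MTT assay, with a stated time of 4 days (a higher number here means that more compound is tolerated, a lower number that less compound is tolerated), only as a limit of that assay: compound 1 gives > 10000 nM. Compound 2 `Cc1cn([C@H]2C[C@H](O)[C@@](C#N)(CO)S2)c(=O)[nH]c1=O` likewise stands at a limit: in this assay compound 2 gives > 10000 nM. The step of cyano in place of azido on a saturated ring carbon, a step that the two limits leave unreadable from compound 1 to compound 2, rests on the limit of > 10000 nM in this assay, at which 2 of the 2 values shown sit, and cannot be sized. Compound 3 `C#C[C@]1(CO)S[C@@H](n2cc(C)c(=O)[nH]c2=O)C[C@@H]1O` carries ethynyl in place of azido on a saturated ring carbon. Within the data shown here, only that unreadable step bears on it, so no step beyond the scatter is expected in this assay; the step from compound 1 to compound 3 is estimated as a step that the limit leaves unreadable from compound 1 to compound 3. Compound 3 is expected at 15000 nM, between 5000 nM and 50000 nM.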

Compound 3, half-maximal cytotoxic concentration: > 10000 nM
Compound 3: only a limit was reported; the forecaster's own chance of this, stated with the estimate: 80%; the middle value is on the limit's open side.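

No step can be read among compound 1, compound 2 and compound 3, each known only as a limit: the limit of > 10000 nM in this assay, at which 3 of the 3 values shown sit.

On these data alone, whether azido, cyano and ethynyl differ in this assay stays open.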